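This account rests on a few compounds, and the source may have more. Where it says the series, first, only, none or still open, it means among the compounds named here.

Measured compounds:
compound 1, `Cn1cc(C2=C(c3n[nH]c4ncccc34)C(=O)N(c3cccc4ccccc34)C2=O)c2ccccc21`, > 100000 nM in a functional assay on A549 cells (Homo sapiens) for antiproliferative activity, read by MTT assay, with a stated time of 48 h; on this read-out higher numbers stand for weaker inhibition and lower numbers for stronger inhibition
compound 2, `Cn1cc(C2=C(c3nn(CCCn4cccc4)c4ncccc34)C(=O)N(c3ccccc3)C2=O)c2ccccc21`, > 100000 nM in this assay

The value for compound 1 in this assay is a limit of the assay, not a number. The value for compound 2 in this assay is likewise a limit. Both values sit at the limit of > 100000 nM in this assay, at which 2 of the 2 values shown sit, so compound 2 stands at the top edge of what was measured, with no numbered value to set it against.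

Compound 3, `Cn1cc(C2=C(c3nn(CCCCn4ccnc4)c4ncccc34)C(=O)N(c3ccccc3)C2=O)c2ccccc21`, is not yet measured. It differs from compound 2 by (1H-imidazol-1-yl)methyl in place of 1H-pyrrol-1-yl on a saturated chain carbon, three bonds along the chain from an aromatic nitrogen. No numbered step exists, so no step size can be read off; with both measured compounds at the limit, the change is expected to stay within the scatter, giving an estimated step that the limit leaves unreadable from compound 2 to compound 3. Compound 3 is expected to give about 150000 nM in this assay, with a range of 20000 nM to 1000000 nM, most likely again as a limit.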

Compound 3, half-maximal inhibitory concentration: 21700 nM
Compound 3: middle estimate off by 6.9-fold (0.84 log units), on the high side; low and high end bracket the measured number.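

In this assay, the end of this chain is shown to matter: 4-(1H-imidazol-1-yl)butyl in place of 3-(1H-pyrrol-1-yl)propyl gives an at least 4.6-fold lower number from compound 2 to compound 3 (0.66 log units; beyond the scatter). Within the data shown here, compound 3 carries the only numbered value so far. The full size of the step cannot be read because compound 2 stands at a limit: the limit of > 100000 nM in this assay, at which 2 of the 3 values shown sit.

The extra ring nitrogen and the longer chain enter together, so 4-(1H-pyrrol-1-yl)butyl and 3-(1H-imidazol-1-yl)propyl would be needed to separate them. From the compounds shown here alone, how an amine in place of the imidazole would read also remains open.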